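The compounds below may be only part of what the source reports. "The series", "measured", "known", "first", "only" and "open" are said of these compounds alone.

Measured compounds:
compound 1, `O=C(NNc1ccc(F)cc1)c1ccc(NS(=O)(=O)c2cnc(O)nc2O)cc1`: > 20000 nM
compound 2, `O=C(NNC(=O)c1ccccc1Cl)c1ccc(NS(=O)(=O)c2cnc(O)nc2O)cc1`: 3240 nM

For the measured compounds named here, in a functional assay on SGC-7901 cells (Homo sapiens) for antiproliferative activity, read by MTT assay, with a stated time of 24 h (on this read-out lower numbers stand for stronger inhibition and higher numbers for weaker inhibition), compound 2 gives 3240 nM, the only plain number among the two compounds measured. For compound 1 the read-out stops at the limit of > 20000 nM in this assay, at which 1 of the 2 values shown sits. Going by the values given here, the one measured step, an at least 6.1-fold lower number from compound 1 to compound 2 (0.79 log units; beyond the scatter), therefore tells only that compound 2 reaches a number where compound 1 does not.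

Compound 3, `O=C(NNC(=O)c1ccc(NS(=O)(=O)c2cnc(O)nc2O)cc1)c1ccc(F)cc1`, keeps the whole core of compound 2 and differs in one place: 4-fluorophenyl in place of 2-chlorophenyl on a carbonyl carbon. Both compounds carry a carbonyl at that position, so the measured step, which exchanged a plain aryl group for an aryl carbonyl on the amine nitrogen, touches this change only indirectly. It gives no direct guidance on swapping one halogenated phenyl for another, and nothing in the two values shown speaks for a large shift in either direction. The step from compound 2 to compound 3 in this assay is expected to stay within the usual scatter, as a 1.2-fold higher number from compound 2 to compound 3 (0.09 log units; within the scatter). Compound 3 is therefore expected to give about 4000 nM, within a range from 1500 nM to 15000 nM.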

Compound 3, half-maximal inhibitory concentration: > 20000 nM
Compound 3 gave a limit, no number; the forecaster's own chance of this, stated with the estimate: 15%; middle value at least 5.0-fold (0.69 log units) away from the limit.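

The exchange of 2-chlorophenyl for 4-fluorophenyl, on a carbonyl carbon whose other neighbour is an amide-type nitrogen, is not a silent one: in this assay it gives an at least 6.1-fold higher number from compound 2 to compound 3 (0.79 log units; beyond the scatter). The earlier step changed what sat on the amine nitrogen, whereas this one shows that an aryl carbonyl there does not by itself secure a measurable number, and that the aryl group on that carbonyl matters. Compound 3 gives only a limit, so the true size of this step stays unknown, the step between compound 1 and compound 3 cannot be read, and compound 2 remains the only compound with a plain number, as the shared ceiling shows: the limit of > 20000 nM in this assay, at which 2 of the 3 values shown sit.

The names 2-chlorophenyl and 4-fluorophenyl differ both in the halogen and in the number that marks its place on the ring, and the compounds shown cannot tell these two changes apart. A 4-chlorophenyl or 2-fluorophenyl group on the same carbonyl carbon would separate them, and a plain phenyl would test whether any halogen is needed at all.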